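The source may hold more compounds than are shown below. What is called first, only, known or untested is meant among the compounds shown, and "the series" means these compounds.

Among the measured compounds shown here, in a functional assay on HepG2 cells (Homo sapiens) for cytotoxicity, read by MTT assay, with a stated time of 48 h (on this read-out lower numbers stand for stronger inhibition and higher numbers for weaker inhibition), compound 1 (`O=C1/C(=C\c2ccccc2)S/C(=N/c2ccccc2)N1Cc1ccncc1`) gives 25200 nM and compound 2 (`O=C1/C(=C\c2ccc(Cl)cc2)S/C(=N/c2ccccc2)N1Cc1ccncc1`) gives 28800 nM with no gap beyond the scatter, so compound 2 stands level with the only other measured number. Compound 3 (`CCOc1cc(/C=C2/S/C(=N/c3ccccc3)N(Cc3ccncc3)C2=O)ccc1O`) has 3-ethoxy-4-hydroxyphenyl in place of 4-chlorophenyl on a double-bonded chain carbon bound to a double-bonded ring carbon. For the measured compounds named here, no measured compound carries hydroxy or ethoxy there. Going by the values given here, with a 1.1-fold higher number from compound 1 to compound 2 (0.06 log units; within the scatter) as the only guide at this place, no step beyond the scatter is expected in this assay and no direction can be argued. The estimated step is a 1.3-fold lower number from compound 2 to compound 3 (0.12 log units; within the scatter) as a working figure. For compound 3 the estimate is 22000 nM with an expected range from 8000 nM to 55000 nM for now.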

Compound 3, half-maximal inhibitory concentration: 20400 nM
Estimate against measurement, compound 3: 1.1-fold (0.03 log units) above; the measured number falls inside the stated range.
By their numbers in this assay, from the lowest: compounds 3, 1 and 2 (each within the scatter of the next).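

In this assay, the place on a double-bonded chain carbon bound to a double-bonded ring carbon now accepts a far greater change than a single chloro: 3-ethoxy-4-hydroxyphenyl gives a 1.4-fold lower number from compound 2 to compound 3 (0.15 log units; within the scatter) and a 1.2-fold lower number from compound 1 to compound 3 (0.09 log units; within the scatter). Phenyl, 4-chlorophenyl and 3-ethoxy-4-hydroxyphenyl thus all stay within the scatter of one another, so adding hydroxy and ethoxy together moves the number no more than chloro does. No supporting data bear on this flat result. Open, going by these compounds, is whether an amine or a carboxylic acid at this place would move the number beyond the scatter. Also open, on these data alone, is whether hydroxy and ethoxy each behave alike when present alone.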